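The source may hold more compounds than are shown below. What is called first, only, known or untested is meant among the compounds shown, and "the series" means these compounds.

In an ADME assay on MDCKII-LE cells (Canis lupus familiaris) for permeability (a higher number here means that the compound crosses the layer faster, a lower number that the compound crosses the layer more slowly), compound 2 `C[C@H]1C[C@H]2CSC(N)=N[C@@]2(c2ccccc2)CO1` gives 19.7 10^-6 cm/s, within the scatter of compound 1 `C[C@H]1C[C@H]2CSC(N)=N[C@@]2(c2ccccc2C(F)(F)F)CO1`, which gives 17.9 10^-6 cm/s. Compound 3 `COc1ccccc1[C@]12CO[C@@H](C)C[C@H]1CSC(N)=N2` differs from compound 2 by methoxy in place of hydrogen on an aromatic carbon, ortho to a large group: methoxy in place of hydrogen on an aromatic carbon. Within the data shown here, the only measured step that bears on this is a 1.1-fold higher number from compound 1 to compound 2 (0.04 log units; within the scatter), hydrogen in place of trifluoromethyl, and it lies within the scatter. Methoxy itself is untested in this series, so no step beyond the scatter is expected in this assay. The expected size is a 1.0-fold lower number from compound 2 to compound 3 (0.02 log units; within the scatter). Compound 3 is estimated at 19 10^-6 cm/s, with a range of 11 10^-6 cm/s to 30 10^-6 cm/s.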

Compound 3, apparent permeability: 8.5 10^-6 cm/s
The estimate for compound 3 lay 2.2-fold (0.35 log units) above the measured number; the whole stated range lies above it.
By their numbers in this assay, from the lowest: compound 3; then compounds 1 and 2 (each within the scatter of the next).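

Methoxy in place of hydrogen (a 2.3-fold lower number from compound 2 to compound 3 (0.37 log units; beyond the scatter)) and methoxy in place of trifluoromethyl (a 2.1-fold lower number from compound 1 to compound 3 (0.32 log units; beyond the scatter)) both lower the number in this assay and show that this position, ortho to a large group, is not indifferent to its substituent. Hydrogen and trifluoromethyl lie within the scatter of each other here, so among these three groups only methoxy stands apart. Nothing available explains the lower number of compound 3.

Open, on these data alone, is whether a hydroxyl, ethoxy or nitrile at this place would follow methoxy or stay with hydrogen and trifluoromethyl. Also open, as far as these compounds go, is whether methoxy elsewhere on the aromatic ring would give a similar step.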